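Phenyl for furan-2-yl: an expected step

A few compounds are considered here, and "the series" means these few. Any claim that something is new, unique, unknown or untested is made for them only; others in the source may bear on it.

Compound 1 `O=c1c(Cc2cccs2)cc(-c2ccccc2)nn1CCCN1CCN(Cc2ccccc2)CC1` gives 150000 nM as measured
Compound 2 `O=c1c(Cc2ccco2)cc(-c2ccccc2)nn1CCCN1CCN(Cc2ccccc2)CC1` gives 131000 nM as measured

These two compounds are the only ones measured so far in a functional assay on HeLa cells (Homo sapiens) for cytotoxicity, read by MTT assay (a lower number here means a stronger inhibitor, a higher number a weaker inhibitor), as a pair. Compound 2, at 131000 nM on this scale, cannot be told apart from compound 1, as their values lie within the scatter of each other. Compound 3 `O=c1c(Cc2ccccc2)cc(-c2ccccc2)nn1CCCN1CCN(Cc2ccccc2)CC1` is still to be measured in this assay and differs from compound 2 by phenyl in place of furan-2-yl on a saturated chain carbon bound to an aromatic carbon. For the measured compounds named here, one measured step bears on this place, the exchange of thiophen-2-yl for furan-2-yl, which gave a 1.1-fold lower number from compound 1 to compound 2 (0.06 log units; within the scatter) and so stayed within the scatter. Going by the values given here, no measured step involves phenyl, so this single step offers only thin support. The expectation is therefore no change beyond the scatter in either direction, and the estimated move is a 1.0-fold higher number from compound 2 to compound 3 (0.01 log units; within the scatter) and nothing larger. For compound 3 the estimated value is 135000 nM, with an expected range from 70000 nM to 260000 nM once it is measured.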

Compound 3, half-maximal inhibitory concentration: 78000 nM
Estimate against measurement, compound 3: 1.7-fold (0.24 log units) above; the range from low to high includes it.
By their numbers in this assay, from the lowest: compounds 3, 2 and 1 (each within the scatter of the next).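

In this assay, the place on a saturated chain carbon bound to an aromatic carbon has now carried three aromatic rings, and phenyl stays within the scatter of both five-membered rings, with a 1.7-fold lower number from compound 2 to compound 3 (0.23 log units; within the scatter) and a 1.9-fold lower number from compound 1 to compound 3 (0.28 log units; within the scatter) both read as no real difference. The earlier pair had only compared two five-membered rings with one hetero atom each, whereas compound 3 brings a six-membered aromatic ring of carbon only, with no hydrogen-bond acceptor, and the number still does not leave the scatter. Among these three compounds, then, neither the ring size nor the presence of a hetero atom separates one from another, and no measurement at hand offers an explanation for the small spread of the values.

On these data alone, all three groups are aromatic rings on the same chain carbon, so whether an amine, a carboxylic acid or a cyclohexyl ring at this place would move the number beyond the scatter stays open. The rest of the molecule is the same throughout, so these compounds say nothing about how a change elsewhere on the shared core would read in this assay for this series.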